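Cyclopropyl Amide to Piperidinyl Urea on a Shared Core

The source may report more compounds than this note shows. Statements on the series, on what has been measured and on what is new or still open speak of the compounds shown alone.

The study follows positive allosteric modulation of the receptor in an assay on HEK293 cells for positive allosteric modulation of metabotropic glutamate receptor 5 (Homo sapiens), read by FLIPR, with a stated time of 1 h; on this read-out lower numbers stand for an effect already at smaller amounts and higher numbers for an effect only at larger amounts of compound. Compound 1 `O=C1c2sc(C#Cc3ccccc3)nc2CN1C1CC1` returns only a limit of the assay, > 10000 nM. Compound 2 `O=C(C1CC1)N1CCc2nc(C#Cc3ccccc3)sc2C1` likewise returns only a limit in this assay, > 10000 nM. Compound 3 `O=C(C1CC(F)(F)C1)N1CCc2nc(C#Cc3cccc(F)c3)sc2C1` is not a single-place neighbour of compound 2. In this assay compound 3 gives 2.5 nM, so the shared core does admit strong modulators. Where compound 2 stands can only be said as a limit, and it shares that position with one other compound, since (the limit of > 10000 nM in this assay, at which 2 of the 3 values shown sit).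

Compound 4 `O=C(N1CCCCC1)N1CCc2nc(C#Cc3ccccc3)sc2C1` differs from compound 2 in one place: piperidin-1-yl in place of cyclopropyl on a carbonyl carbon. For the measured compounds named here, no measured step of this kind is available, so the size of the change cannot be read from the data. Because compound 2 gives > 10000 nM, the starting point is itself a limit, and the step from compound 2 to compound 4 is expected to be small, an at least 1.2-fold lower number from compound 2 to compound 4 (0.09 log units; that floor lies within the scatter), not clearly beyond the usual scatter. Compound 4 is therefore estimated at 8000 nM, with a range from 1500 nM to 30000 nM, and a real chance that this assay again reports only a limit.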

Compound 4, half-maximal effective concentration: 75 nM
Estimate against measurement, compound 4: 110-fold (2.03 log units) above; the measured number lies below the stated range.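

Piperidin-1-yl in place of cyclopropyl on a carbonyl carbon brings an at least 130-fold lower number from compound 2 to compound 4 (2.12 log units; beyond the scatter) in this assay, so a change at this one place is enough to lift a compound of the shared core off the assay limit, which no earlier compound could show as none of them formed a single-place pair. The group on this carbonyl carbon therefore has a large bearing on the read-out, at least with the unsubstituted phenyl kept in both compounds. The true size of the step remains unknown, and only its floor can be stated, because compound 2 stands at a limit and not at a number: the limit of > 10000 nM in this assay, at which 2 of the 4 values shown sit.

The change replaces a three-membered ring of carbon only with a six-membered ring holding a nitrogen, and this single pair cannot separate the effect of the ring size from that of the nitrogen on the carbonyl carbon. From the compounds shown here alone, what a pyrrolidin-1-yl, a morpholin-4-yl or an open dimethylamino group would do at the same place stays open, as does whether the step would keep its size on a core carrying another aryl group.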